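Adding an Ethoxy Group to Compound 2: Expected Cytotoxicity

The compounds below may be only part of what the source reports. "The series", "measured", "known", "first", "only" and "open" are said of these compounds alone.

Compound 1, `O=C(CC1SC(=O)NC1=O)Oc1ccc(/C=N/NC(=O)c2ccncc2)cc1Br`: 190 ug/mL in an ADME assay on Vero cells (Chlorocebus sabaeus) for cytotoxicity, read by MTT assay, with a stated time of 24 h; on this read-out higher numbers stand for weaker inhibition and lower numbers for stronger inhibition
Compound 2, `O=C(CC1SC(=O)NC1=O)Oc1ccc(/C=N/NC(=O)c2ccncc2)cc1`: 91.7 ug/mL
Compound 3, `O=C(/C=C1/SC(=O)NC1=O)Oc1cccc(/C=N\NC(=O)c2ccncc2)c1`: 143 ug/mL

Compound 2 gives the lowest of the three numbers in this assay. Compound 3 lies within the usual scatter of it, while compound 1 sits a clear step higher; that step, a 2.1-fold lower number from compound 1 to compound 2 (0.32 log units; beyond the scatter), is modest and goes with hydrogen in place of bromo on an aromatic carbon. Compound 4, `CCOc1cc(/C=N/NC(=O)c2ccncc2)ccc1OC(=O)CC1SC(=O)NC1=O`, differs from compound 2 by ethoxy in place of hydrogen on an aromatic carbon. Among the compounds with values here, no measured step adds a group to this ring, so the only guide is the single modest step seen when bromo was removed. For compound 4 a small move, if any, toward a higher number is expected: a 1.3-fold higher number from compound 2 to compound 4 (0.12 log units; within the scatter). Compound 4 is estimated at 120 ug/mL, with a range from 60 ug/mL to 240 ug/mL.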

Compound 4, half-maximal inhibitory concentration: 50.9 ug/mL
The estimate for compound 4 lay 2.4-fold (0.37 log units) above the measured number; measured number below the stated range.
By their numbers in this assay, from the lowest: compounds 4, 2, 3 and 1 (each within the scatter of the next, the first and the last beyond it).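

On this aromatic carbon, ortho to a large group and meta to a large group, ethoxy in place of hydrogen gives a 1.8-fold lower number from compound 2 to compound 4 (0.26 log units; within the scatter), so a group of 3 heavy atoms fits here without a change beyond the scatter. Ethoxy in place of bromo on the same carbon gives a 3.7-fold lower number from compound 1 to compound 4 (0.57 log units; beyond the scatter), which shows that in this assay the choice between these two groups makes a modest difference. Nothing available here explains that difference. On these data alone, it remains open whether an amine, a carboxylic acid or a longer chain on this carbon would read closer to ethoxy or to bromo.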